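The source may hold more compounds than are shown below. What is called first, only, known or untested is meant among the compounds shown, and "the series" means these compounds.

Working notes on the sulfonamide series. In a functional assay (trachea) for antagonist activity, with Cavia porcellus as the target (a lower number here means a less potent compound, a higher number a more potent compound, by a factor of ten per unit of this negative logarithm), compound 2 `COc1cc(C(=O)NS(=O)(=O)c2cccs2)ccc1Cn1ccc2ccc(NC(=O)CC3CCCC3)cc21` gives 9.6, the highest of the three numbers; compound 1 `CCCCC(CC)C(=O)Nc1ccc2ccn(Cc3ccc(C(=O)NS(=O)(=O)c4ccc(F)cc4)cc3OC)c2c1` gives 7.7 and compound 3 `CCCCC(CC)C(=O)Nc1ccc2ccn(Cc3ccc(C(=O)NS(=O)(=O)c4ccccc4)cc3)c2c1` gives 6.8, both beyond the scatter below compound 2. Compound 1 and compound 3 differ from compound 2 in more than one place, so no single step can be read from them. Compound 4 `COc1cc(C(=O)NS(=O)(=O)c2ccccc2N)ccc1Cn1ccc2ccc(NC(=O)CC3CCCC3)cc21` is the next one to be measured. Its difference from compound 2 is 2-aminophenyl in place of thiophen-2-yl on a sulfonyl sulfur. Among the measured compounds shown here, no measured pair shows this change; the expectation is a modest loss in this assay, a step of a number 0.50 log units lower from compound 2 to compound 4 (beyond the scatter), and compound 4 is estimated at 9.1 with a range from 8.3 to 9.7.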

Compound 4, negative logarithm of the antagonist equilibrium constant: 9.9
Compound 4: middle estimate off by 0.80 log units, on the low side; measured number outside the range, above it.
By their numbers in this assay, from the lowest: compound 3; then compound 1; then compounds 2 and 4 (each within the scatter of the next).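

On a sulfonyl sulfur whose other neighbour is an amide-type nitrogen, 2-aminophenyl in place of thiophen-2-yl gives in this assay a number 0.30 log units higher from compound 2 to compound 4 (within the scatter). This position therefore accepts a six-membered aromatic ring of carbon only, carrying a hydrogen-bond donor, in place of a five-membered aromatic ring with a sulfur, without a step beyond the scatter. Nothing available bears on why the step is this small.

Ring and amine change together here, so their separate contributions remain unresolved. A hydroxyl or a carboxylic acid in place of the amine remains an open comparison.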